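From Thiophen-2-yl to 4-Nitrophenyl on the Carbonyl Carbon

The source may report more compounds than this note shows. Statements on the series, on what has been measured and on what is new or still open speak of the compounds shown alone.

Among the compounds with values here, compound 1 `COc1cc(-c2nnc3n2NC(c2ccco2)C(C(=O)c2cccs2)S3)cc(OC)c1OC` is the only member of this small set with a measured number rather than a limit. In a functional assay on HepG2 cells (Homo sapiens) for cytotoxicity, read by MTT assay, with a stated time of 48 h (on this read-out higher numbers stand for weaker inhibition and lower numbers for stronger inhibition), compound 1 gives 64100 nM. Compound 2 `COc1cc(-c2nnc3n2NC(c2ccco2)C(C(=O)c2ccc(-c4ccccc4)cc2)S3)cc(OC)c1OC` carries a 4-phenylphenyl on the carbonyl carbon instead, and in this assay compound 2 reaches only the limit of the assay, > 100000 nM. Compound 3 `COc1cc(C(=O)C2Sc3nnc(-c4cc(OC)c(OC)c(OC)c4)n3NC2c2ccco2)cc(OC)c1OC` places a 3,4,5-trimethoxyphenyl on that carbonyl carbon, and in this assay compound 3 likewise stops at the limit, > 100000 nM. The two measured steps read an at least 1.5-fold higher number from compound 1 to compound 2 (0.19 log units; that floor lies within the scatter) and an at least 1.5-fold higher number from compound 1 to compound 3 (0.19 log units; that floor lies within the scatter), while a third step reads a step that the two limits leave unreadable from compound 2 to compound 3.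

Compound 4 `COc1cc(-c2nnc3n2NC(c2ccco2)C(C(=O)c2ccc([N+](=O)[O-])cc2)S3)cc(OC)c1OC` has not been measured. It differs from compound 1 in one place: 4-nitrophenyl in place of thiophen-2-yl on a carbonyl carbon. Both measured replacements of the thiophen-2-yl on the carbonyl carbon, in compound 2 and compound 3, gave higher numbers that ran into the limit (the limit of > 100000 nM in this assay, at which 2 of the 3 values shown sit). A similar weakening is therefore expected for compound 4, that is, a step of a 1.6-fold higher number from compound 1 to compound 4 (0.19 log units; within the scatter) is expected. For compound 4 the estimate in this assay is 100000 nM, with a range from 45000 nM to 250000 nM, and a fair chance that only the limit is reported.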

Compound 4, half-maximal inhibitory concentration: 87800 nM
Compound 4: middle estimate off by 1.1-fold (0.06 log units), on the high side, and the stated range covers the measured number.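

Compound 4 is the only replacement of thiophen-2-yl on the carbonyl carbon that gives a measured number rather than a limit: in this assay, 4-nitrophenyl in place of thiophen-2-yl gives a 1.4-fold higher number from compound 1 to compound 4 (0.14 log units; within the scatter), so a six-membered aromatic ring of carbon only, bearing a nitro group, can stand here without a change that can be told from the scatter. The comparisons with the other two replacements read an at least 1.1-fold lower number from compound 3 to compound 4 (0.05 log units; that floor lies within the scatter) and an at least 1.1-fold lower number from compound 2 to compound 4 (0.05 log units; that floor lies within the scatter), and since each is only a floor within the scatter, neither separates the compounds. The reading of this position therefore still rests on only two true numbers: the limit of > 100000 nM in this assay, at which 2 of the 4 values shown sit.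

The compounds shown leave open whether any group on this carbonyl carbon can bring the number clearly below that of compound 1, for instance an amine or a short alkyl chain in place of the aromatic ring. They also leave open whether the nitro group itself matters, which a 4-aminophenyl or a 4-carboxyphenyl on the same carbonyl carbon could begin to test.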